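The source may hold more compounds than are shown below. What is called first, only, known or untested is meant among the compounds shown, and "the series" means these compounds.

Working notes on the series.

Compound 1 `Cc1cc(-c2cnn3c(NCC4CCOCC4)nc(Oc4cccc(F)c4F)nc23)ccc1C(=O)NC1CC1` is one of two compounds with a number in an ADME assay on microsomes (Rattus norvegicus) for metabolic stability (a lower number here means that the compound disappears faster, a higher number that the compound lasts longer), so far. In this assay compound 1 gives 0.667 h. Compound 2 `Cc1cc(-c2cnn3c(NCC4CCOCC4)nc(Nc4cccc(F)c4)nc23)ccc1C(=O)NC1CC1` differs from it in one place only, and in this assay compound 2 gives 0.65 h. The step of a 1.0-fold lower number from compound 1 to compound 2 (0.01 log units; within the scatter) is within the scatter, so the two numbers cannot be ordered against each other, and compound 1 stands simply level with compound 2.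

Compound 3 `Cc1cc(-c2cnn3c(NCC4CCOCC4)nc(Nc4ccccc4F)nc23)ccc1C(=O)NC1CC1` has not been measured in this assay. It differs from compound 1 by (2-fluorophenyl)amino in place of 2,3-difluorophenoxy on an aromatic carbon. Among the measured compounds shown here, the one measured step that bears on this change is a 1.0-fold lower number from compound 1 to compound 2 (0.01 log units; within the scatter), which exchanged the same group at the same place for a (3-fluorophenyl)amino group and left the half-life unchanged beyond the scatter. The change to compound 3 is of the same kind, an amino-linked fluorophenyl in place of the difluorophenoxy, so no step beyond the scatter is expected here either, that is a 1.0-fold lower number from compound 1 to compound 3 (0.01 log units; within the scatter). Compound 3 is therefore expected to give about 0.65 h in this assay, with a range of 0.35 h to 1.2 h.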

Compound 3, half-life: 0.717 h
Estimate against measurement, compound 3: 1.1-fold (0.04 log units) below; low and high end bracket the measured number.
By their numbers in this assay, from the lowest: compounds 2, 1 and 3 (each within the scatter of the next).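

In this assay, a second amino-linked fluorophenyl on this aromatic carbon between two ring nitrogen atoms gives the same reading as the first: (2-fluorophenyl)amino in place of 2,3-difluorophenoxy amounts to a 1.1-fold higher number from compound 1 to compound 3 (0.03 log units; within the scatter) and so adds a second exchange of the oxygen-linked group for a nitrogen-linked one that stays inside the scatter. The new information is the comparison within the amino-linked pair, where 2-fluorophenyl in place of 3-fluorophenyl on the nitrogen gives a 1.1-fold higher number from compound 2 to compound 3 (0.04 log units; within the scatter) and the position of the single fluorine on the ring therefore does not separate these two compounds. Nothing at hand accounts for the half-life staying level across these three compounds.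

As far as these compounds go, all three compounds keep a fluorinated phenyl ring at this position, so it remains open whether an unsubstituted phenyl, a saturated amine such as morpholine or a small alkoxy group would stay level with them or move the half-life beyond the scatter. The ((oxan-4-yl)methyl)amino group and the cyclopropyl amide are also common to all three, which leaves open how the half-life responds to a change at either of those places, for example a longer chain in place of the oxane or a carboxylic acid in place of the amide.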